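Series notes: from compound 3 to compound 4

The source may hold more compounds than are shown below. What is called first, only, known or untested is meant among the compounds shown, and "the series" means these compounds.

The three measured compounds share one core. Compound 1 `Fc1ccc(C(F)(F)F)cc1Nc1nc2nonc2nc1Nc1cc(C(F)(F)F)ccc1F` carries trifluoromethyl and fluorine on both outer aromatic rings; in an assay on mitochondria from L6 cells (Rattus norvegicus) for activation, with a stated time of 90 min (on this read-out higher numbers stand for an effect only at larger amounts of compound and lower numbers for an effect already at smaller amounts), compound 1 reaches < 1000 nM, which is a limit of the assay and not a number, and the limit of < 1000 nM in this assay, at which 1 of the 3 values shown sits, shows where it sits. Compound 2 `FC(F)(F)c1ccccc1Nc1nc2nonc2nc1Nc1ccccc1C(F)(F)F` carries trifluoromethyl on each outer ring and gives 1000 nM in this assay. Compound 3 `Fc1ccccc1Nc1nc2nonc2nc1Nc1ccccc1`, with one fluorine on one outer ring and the other ring bare, gives 2200 nM in this assay, the highest of the two numbers shown; its nearest neighbour is compound 2, and that gap lies beyond the scatter.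

Compound 4 `COc1ccc(Nc2nc3nonc3nc2Nc2ccccc2F)cc1` has not been measured. It differs from compound 3 by methoxy in place of hydrogen on an aromatic carbon. Within the data shown here, no measured pair shows this change, so no step size is known from the series. The step of a 1.3-fold lower number from compound 3 to compound 4 (0.11 log units; within the scatter) is expected to be small, within the usual scatter, with no direction claimed. Compound 4 is therefore estimated at 1700 nM in this assay, with a range from 600 nM to 4500 nM.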

Compound 4, half-maximal effective concentration: 1600 nM
Beside the measured number, compound 4's estimate is 1.1-fold (0.03 log units) above it; the measured number falls inside the stated range.
By their numbers in this assay, from the lowest: compounds 2, 4 and 3 (each within the scatter of the next, the first and the last beyond it).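

Among these compounds, compound 3 and compound 4 form the first pair that differs in one place, so the change from phenyl to 4-methoxyphenyl can now be read directly: in this assay it gives a 1.4-fold lower number from compound 3 to compound 4 (0.14 log units; within the scatter). Among the compounds shown here, at this aromatic carbon, para to a large group, methoxy in place of hydrogen therefore gives no step that can be told from the scatter, a result the earlier compounds could not show. Nothing shown bears on the reason for this step.

From the compounds shown here alone, whether the same holds for another group at this carbon, such as an amine or a carboxylic acid, remains open. Also open, going by these compounds, is what methoxy does at another carbon of this ring, or on the ring that carries the fluorine.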